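The source may hold more compounds than are shown below. What is called first, only, known or untested is meant among the compounds shown, and "the series" means these compounds.

Three compounds were examined in a functional assay on CHO cells for agonist activity at metabotropic glutamate receptor 2 (Homo sapiens), read by FLIPR; a higher number here means that more compound is needed for the effect, a lower number that less compound is needed. Compound 1 `Cn1c(CN2CCC(c3ccccc3C(F)(F)F)CC2)nc2ccccc21` gives 6310 nM. Compound 2 `Cn1c(CN2CCN(c3ccccc3F)CC2)nc2ccccc21` gives 6310 nM. Compound 3 `Cn1c(CN2CCN(c3ccccc3C(F)(F)F)CC2)nc2ccccc21` reaches only > 15800 nM, which is a limit of this assay and not a number. The difference between the core of compound 3 and the core of compound 1 is not broken down here. Going fluoro in place of trifluoromethyl on an aromatic carbon produced an at least 2.5-fold lower number from compound 3 to compound 2 (0.39 log units; beyond the scatter), a step that rests on the limit of > 15800 nM in this assay, at which 1 of the 3 values shown sits, and so marks a floor rather than a full size. Compound 1 stands level with compound 2 in this assay, within the scatter. Compound 4 `Cn1c(CN2CCC(c3ccccc3F)CC2)nc2ccccc21` has not yet been measured; it differs from compound 1 by fluoro in place of trifluoromethyl on an aromatic carbon, the same change as from compound 3 to compound 2. Compound 4 is expected to show a 2.5-fold lower number from compound 1 to compound 4 (0.40 log units; beyond the scatter), a lowering of similar size. Compound 4 is estimated at 2500 nM, with a range from 800 nM to 8000 nM.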

Compound 4, half-maximal effective concentration: 3980 nM
Estimate against measurement, compound 4: 1.6-fold (0.20 log units) below; the range from low to high includes it.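

In this assay, fluoro in place of trifluoromethyl on an aromatic carbon gave a 1.6-fold lower number from compound 1 to compound 4 (0.20 log units; within the scatter), so on this core the change does not produce a shift beyond the scatter. This does not show that the earlier step carries over in full to the core of compound 1, nor does it show that the two steps differ: the same change on two cores in this assay, an at least 2.5-fold lower number (0.39 log units; beyond the scatter) from compound 3 to compound 2 and a 1.6-fold lower number (0.20 log units; within the scatter) from compound 1 to compound 4; the limit leaves it open whether they differ. Compound 3 stands at a limit and not a number, so the earlier step has no full size to compare: the limit of > 15800 nM in this assay, at which 1 of the 4 values shown sits.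

The compounds shown leave open what a chloro, methyl or nitrile group on the same aromatic carbon would do on either core. They also leave open whether the change would behave alike on a third core.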